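Halogen Swap on an Anilide Versus Its Cyclic Counterpart

The source may report more compounds than this note shows. Statements on the series, on what has been measured and on what is new or still open speak of the compounds shown alone.

Measured so far:
- Compound 1 `O=c1oc2ccc(F)cc2c(=O)n1-c1ccc(I)cc1F`: 6000 nM
- Compound 2 `O=C(Nc1ccc(Cl)cc1F)c1cc(F)ccc1O`: 7700 nM
- Compound 3 `O=c1oc2ccc(F)cc2c(=O)n1-c1ccc(Cl)cc1F`: 7900 nM

Of the compounds shown here, three have been tested in an ADME assay on RAW264.7 cells (Mus musculus) for cytotoxicity, read by MTT assay, with a stated time of 24 h; on this read-out higher numbers stand for lower toxicity in this test and lower numbers for higher toxicity in this test. Compound 1 and compound 3 share a core and differ in one place: iodo in place of chloro on an aromatic carbon. In this assay the step of a 1.3-fold lower number from compound 3 to compound 1 (0.12 log units; within the scatter).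

Compound 2 has a different core; the difference between the two cores is not broken down here. In this assay compound 2 gives 7700 nM, and its values and those of compound 1 and compound 3 all lie within the scatter of one another, so no order among the three can be read from them.

Compound 4 `O=C(Nc1ccc(I)cc1F)c1cc(F)ccc1O` has not been measured. It relates to compound 2 as compound 1 relates to compound 3: iodo in place of chloro on an aromatic carbon. The two changes read the same. It is the same change, made on a different core. For the measured compounds named here, the only guidance is the step of a 1.3-fold lower number from compound 3 to compound 1 (0.12 log units; within the scatter), which stayed within the scatter.

On that basis the step from compound 2 to compound 4 is expected to be about a 1.3-fold lower number from compound 2 to compound 4 (0.11 log units; within the scatter) in this assay, resting on the earlier step and on the value of compound 2 7700 nM. Compound 4 is therefore estimated at 6000 nM, with a range from 3000 nM to 12000 nM.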

Compound 4, half-maximal cytotoxic concentration: 7400 nM
Compound 4: middle estimate off by 1.2-fold (0.09 log units), on the low side, and the stated range covers the measured number.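

On the core of compound 2, iodo in place of chloro on an aromatic carbon leaves the number in this assay within the scatter, the step being a 1.0-fold lower number from compound 2 to compound 4 (0.02 log units; within the scatter). Set beside the same change on the core of compound 1 and compound 3, the two steps cannot be told apart: the same change on two cores in this assay, a 1.3-fold lower number (0.12 log units; within the scatter) from compound 3 to compound 1 and a 1.0-fold lower number (0.02 log units; within the scatter) from compound 2 to compound 4, 1.3-fold (0.10 log units) apart, within the scatter of two such steps. This shows that, across these two cores, the swap moved the number by no more than the scatter on either one and that the two cores gave no sign of responding differently, but it does not show that the change has a real effect of its own that carries over, since neither step can be separated from repeat-to-repeat variation, and two cores in one test are a narrow base for any wider rule.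

The compounds shown carry only chloro and iodo in this place, so it stays open whether an amine, a carboxylic acid or a longer chain there would give a step large enough to read. Going by these compounds, it also stays open whether such a step would then hold from one core to the other, which the present pairs cannot test.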